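The source may hold more compounds than are shown below. What is called first, only, known or untested is meant among the compounds shown, and "the series" means these compounds.

In a functional assay on V79 cells (Cricetulus griseus) for cytotoxicity, read by colony formation (a lower number here means a stronger inhibitor, a higher number a weaker inhibitor), compound 1 (`CC1(CN)CCN(c2c(F)cc3c(=O)c(C(=O)O)cn(C4CC4)c3c2F)C1`) gives 8 ug/mL and compound 2 (`CNCC1(C)CCN(c2c(F)cc3c(=O)c(C(=O)O)cn(C4CC4)c3c2F)C1`) gives 8 ug/mL, level at the digits shown and together the lowest of the three numbers, while compound 3 (`CNCC1(C)CCN(c2c(F)cc3c(=O)c(C(=O)O)cn(C4CC4)c3c2Cl)C1`) gives 23 ug/mL. Compound 4 (`NC1CCN(c2c(F)cc3c(=O)c(C(=O)O)cn(C4CC4)c3c2F)CC1`) is still unmeasured and departs from compound 2 by 4-aminopiperidin-1-yl in place of 3-methyl-3-((methylamino)methyl)pyrrolidin-1-yl on an aromatic carbon. Methyl in place of hydrogen on an amine nitrogen gave no change at the digits printed from compound 1 to compound 2 (within the scatter), and chloro in place of fluoro on an aromatic carbon gave a 2.9-fold higher number from compound 2 to compound 3 (0.46 log units; beyond the scatter). Neither step exchanges the whole group, so both bear on this change only loosely. A modest rise at most is expected, a 1.5-fold higher number from compound 2 to compound 4 (0.18 log units; within the scatter). Compound 4 is estimated at 12 ug/mL, with an expected range of 4 ug/mL to 35 ug/mL.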

Compound 4, half-maximal inhibitory concentration: 23 ug/mL
The estimate for compound 4 lay 1.9-fold (0.28 log units) below the measured number; the measured number falls inside the stated range.
By their numbers in this assay, from the lowest: compounds 1 and 2 (each within the scatter of the next); then compounds 3 and 4 (each within the scatter of the next).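

In this assay, exchanging the whole amine-bearing ring on this aromatic carbon for 4-aminopiperidin-1-yl gives a 2.9-fold higher number from compound 2 to compound 4 (0.46 log units; beyond the scatter) and a 2.9-fold higher number from compound 1 to compound 4 (0.46 log units; beyond the scatter), so the number responds to this exchange, whereas methyl on the amine nitrogen left it unchanged. The result holds whether the group leaving carries the methylamino or the unsubstituted aminomethyl arm. Nothing measured here explains the rise.

Ring size, the ring methyl and the amine's placement all change together, so their separate contributions remain open. A 3-aminopyrrolidin-1-yl or piperazin-1-yl group on this carbon would help to separate them.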